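Solubility of a pyridyl ether within a shared benzimidazole-type series

The compounds below may be only part of what the source reports. "The series", "measured", "known", "first", "only" and "open" are said of these compounds alone.

Measured compounds:
- compound 1 `Cc1ccc(Oc2ccc3nc(COc4cccc(C(=O)O)c4)n(C)c3n2)cc1C`: 16 ug/mL
- compound 2 `Cn1c(COc2cccc(C(=O)O)c2)nc2ccc(Oc3ccc4c(c3)CCC4)nc21`: 4.3 ug/mL
- compound 3 `Cn1c(COc2cccc(C(=O)O)c2)nc2ccc(Oc3cc(Cl)ccn3)cc21`: 11 ug/mL

In a physicochemical assay for solubility, read by HPLC, measured as thermodynamic solubility, with a stated time of 4 h, at pH 6.8 (a higher number here means a more soluble compound, a lower number a less soluble compound), compound 3 gives 11 ug/mL, the second highest of the three numbers. Its nearest neighbour is compound 1, which gives 16 ug/mL, a gap within the scatter, so no order between them can be claimed. Compound 2, with 4.3 ug/mL, lies furthest from compound 3, and that gap is beyond the scatter.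

Compound 4 `Cc1cc(F)cnc1Oc1ccc2nc(COc3cccc(C(=O)O)c3)n(C)c2c1` differs from compound 3 in one place: 5-fluoro-3-methylpyridin-2-yl in place of 4-chloropyridin-2-yl on an oxygen on an aromatic ring. For the measured compounds named here, the only measured step, a 3.7-fold lower number from compound 1 to compound 2 (0.57 log units; beyond the scatter), concerns a different exchange on the same oxygen and offers no direct guide to this change. Going by the values given here, no measured pair carries the present exchange, so the account expects no step beyond the scatter, a 1.1-fold higher number from compound 3 to compound 4 (0.04 log units; within the scatter), in this assay. Compound 4 is therefore estimated at 12 ug/mL, with a range from 4 ug/mL to 35 ug/mL.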

Compound 4, solubility: 14 ug/mL
Estimate against measurement, compound 4: 1.2-fold (0.07 log units) below, within the range that was stated.
By their numbers in this assay, from the lowest: compound 2; then compounds 3, 4 and 1 (each within the scatter of the next).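

For the compounds shown here, compound 3 and compound 4 offer the first measured exchange of one substituted pyridinyl group for another on this oxygen on an aromatic ring, and a 1.3-fold higher number from compound 3 to compound 4 (0.10 log units; within the scatter) in this assay gives them no order. The entering group differs from the leaving group in its halogen, its methyl and the placing of both, so this step reads these differences only as one exchange and cannot separate them. Nothing available explains this result.

On these data alone, whether fluorine or methyl alone on the pyridine ring would leave the number within the scatter remains open. Also open, as far as these compounds go, is how this assay would respond to an amine on that ring, or to a longer chain in place of the methyl of compound 4.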